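Shortening the Chain on the Core of Compound 3

A few compounds are considered here, and "the series" means these few. Any claim that something is new, unique, unknown or untested is made for them only; others in the source may bear on it.

Compound 1 `CCCCCCn1cnc2c(Nc3ccc(O)cc3)nc(N[C@H]3CC[C@H](N)CC3)nc21`: 5400 nM
Compound 2 `CC(C)CCn1cnc2c(Nc3cccc(O)c3)nc(N[C@H]3CC[C@H](N)CC3)nc21`: 7600 nM
Compound 3 `CCCCCCn1cnc2c(Nc3cccc(Cl)c3)nc(N[C@H]3CC[C@H](N)CC3)nc21`: 2300 nM

Of the compounds shown here, three have been measured in a functional assay on K562 cells (Homo sapiens) for inhibition, read by fluorescence, with a stated time of 72 h; on this read-out lower numbers stand for stronger inhibition of growth and higher numbers for weaker inhibition of growth. Compound 3 gives the lowest number of the three in this assay; compound 1 stands somewhat higher and compound 2 higher still, and both gaps lie beyond the scatter. For the measured compounds named here, the only measured step between compounds that differ in one place is a 2.3-fold lower number from compound 1 to compound 3 (0.37 log units; beyond the scatter), a modest change.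

Compound 4 `CCCCn1cnc2c(Nc3cccc(Cl)c3)nc(N[C@H]3CC[C@H](N)CC3)nc21` keeps the chlorophenyl group of compound 3 and alters only the chain: hydrogen in place of ethyl on a saturated chain carbon, four bonds along the chain from an aromatic nitrogen. Going by the values given here, no measured pair isolates this change. Compounds 1 and 2 carry chains of different length, but they also differ in their hydroxyphenyl group, so their values cannot be read as a chain effect. With nothing to lean on, the expected step in this assay is small, most likely within the scatter, and its direction is uncertain. Compound 4 is expected to give about 3000 nM, between 1400 nM and 7000 nM. This estimate means a step of a 1.3-fold higher number from compound 3 to compound 4 (0.12 log units; within the scatter) is expected.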

Compound 4, concentration for 50% growth inhibition: 2000 nM
Beside the measured number, compound 4's estimate is 1.5-fold (0.18 log units) above it, within the range that was stated.
By their numbers in this assay, from the lowest: compounds 4 and 3 (each within the scatter of the next); then compounds 1 and 2 (each within the scatter of the next).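

In this assay, hydrogen in place of ethyl on a saturated chain carbon, four bonds along the chain from an aromatic nitrogen, gives a 1.2-fold lower number from compound 3 to compound 4 (0.06 log units; within the scatter). For the compounds shown here, this is the first measured pair that isolates the chain, and with the 3-chlorophenyl group held fixed, compound 3 and compound 4 cannot be told apart in this read-out, even though 2 carbon atoms have gone. No supporting measurement is available to explain this result.

The compounds shown leave open whether a methyl chain, a longer chain or an amine on the chain would be tolerated in the same way. They also leave open whether the same change would give a similar step with a hydroxyphenyl group in place of the 3-chlorophenyl group.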